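One Inverted Stereocentre and the Cytotoxicity Read-Out

The source may report more compounds than this note shows. Statements on the series, on what has been measured and on what is new or still open speak of the compounds shown alone.

In a functional assay on MCF7 cells (Homo sapiens) for cytotoxicity, read by MTT assay, with a stated time of 48 h (on this read-out lower numbers stand for stronger inhibition and higher numbers for weaker inhibition), compound 3 `COC(=O)C[C@@H]1c2c(-c3ccc(O)cc3OC)cc(O)c(O)c2C[C@@H]1C(C)(C)O` gives 6700 nM. Compound 2 `COc1cc(O)ccc1C(=O)C[C@H]1c2ccc(O)c(O)c2C[C@@H]1C(C)(C)O` gives 3900 nM, and compound 1 `COc1cc(O)ccc1C(=O)C[C@@H]1c2ccc(O)c(O)c2C[C@H]1C(C)(C)O` gives 3300 nM. The gap between compound 3 and compound 2 lies within the scatter, while the gap between compound 3 and compound 1 lies outside it.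

Compound 4 `COC(=O)C[C@@H]1c2c(-c3ccc(O)cc3OC)cc(O)c(O)c2C[C@H]1C(C)(C)O` has not yet been measured. Its relation to compound 3 is purely one of configuration: the two compounds have the same atoms and bonds and differ only in configuration as drawn: 1 of 2 stereo elements differ; a stereocentre at a saturated ring carbon is drawn S in compound 3 and R in compound 4.

Among the measured compounds shown here, one measured step bears on this change: a 1.2-fold higher number from compound 1 to compound 2 (0.07 log units; within the scatter), which stays within the scatter. Its relevance lies in the fact that compounds 1 and 2 differ only in the configuration as drawn. That pair are mirror images with all stereocentres inverted, whereas here only one of two stereo elements differs, so the precedent is indirect. Still, it offers no sign that configuration moves the number in this assay appreciably, and no direction can be drawn from it.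

The expected change is therefore no more than scatter, an estimated 1.2-fold lower number from compound 3 to compound 4 (0.09 log units; within the scatter). For compound 4 the estimated value is 5500 nM, with an expected range from 2600 nM to 11000 nM.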

Compound 4, half-maximal inhibitory concentration: 7200 nM
Beside the measured number, compound 4's estimate is 1.3-fold (0.12 log units) below it, within the range that was stated.
By their numbers in this assay, from the lowest: compounds 1, 2, 3 and 4 (each within the scatter of the next, the first and the last beyond it).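

Inverting a single stereocentre at a saturated ring carbon gives a 1.1-fold higher number from compound 3 to compound 4 (0.03 log units; within the scatter) in this assay. The earlier pair, with a 1.2-fold higher number from compound 1 to compound 2 (0.07 log units; within the scatter), had shown only both stereocentres inverted together, so it could not say what one centre does alone. This change can be read as configuration at that one centre and nothing else, because the structures allow no other reading: the fact that compounds 3 and 4 differ only in the configuration as drawn

The compounds shown leave open what the other stereocentre does when it alone is inverted. They also cannot tell whether the number would stay as close across such an inversion if a carboxylic acid or an amine were carried on the shared core.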